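Phenyl for Thiophene on the Diamino Core

This account rests on a few compounds, and the source may have more. Where it says the series, first, only, none or still open, it means among the compounds named here.

Compound 1 `Nc1nc(N)c2c(-c3ccsc3)cn([C@@H]3O[C@H](CO)[C@@H](O)[C@H]3O)c2n1` is known in a functional assay on A549 cells (Homo sapiens), read by MTT assay, with a stated time of 72 h (a lower number here means a stronger inhibitor, a higher number a weaker inhibitor), only as a limit: compound 1 gives > 100000 nM. Its neighbour compound 3 `Cc1nc(N)c2c(-c3ccsc3)cn([C@@H]3O[C@H](CO)[C@@H](O)[C@H]3O)c2n1` is likewise a limit, and compound 3 gives > 20000 nM. The step from compound 1 to compound 3, a step that the two limits leave unreadable from compound 1 to compound 3, is therefore unreadable, as both the limit of > 100000 nM in this assay, at which 1 of the 3 values shown sits, and the limit of > 20000 nM in this assay, at which 1 of the 3 values shown sits, show. Compound 2 `COc1ncnc2c1c(-c1ccsc1)cn2[C@@H]1O[C@H](CO)[C@@H](O)[C@H]1O`, with a different core, gives 5170 nM in this assay. Compound 4 `Nc1nc(N)c2c(-c3ccccc3)cn([C@@H]3O[C@H](CO)[C@@H](O)[C@H]3O)c2n1` arises from compound 1 by phenyl in place of thiophen-3-yl on an aromatic carbon. For the measured compounds named here, no measured step touches this change, so no size can be read from the data. Compound 4 is expected to remain near the limit, with an estimated value of 150000 nM (range 30000 nM to 800000 nM); the expected step is a step that the limit leaves unreadable from compound 1 to compound 4.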

Compound 4, half-maximal inhibitory concentration: > 20000 nM
Compound 4 ended at the assay's limit (the forecaster's own chance of this, stated with the estimate: 75%); the middle value is on the limit's open side.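

Compound 1 and compound 4 both stand only as limits in this assay, and the step between them cannot be read. The compounds shown leave open whether phenyl and thiophen-3-yl differ at all on the shared core.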